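Amide-to-sulfonamide swap on the anilide arm

This account rests on a few compounds, and the source may have more. Where it says the series, first, only, none or still open, it means among the compounds named here.

Three compounds in this series have numbers in an assay on isolated protein for inhibition of Rho-associated protein kinase 2 (Homo sapiens), read by scintillation counting, radiometric assay and 33P incorporation, with a stated time of 40 min, in the presence of a further agent that is not named here; a higher number here means a weaker inhibitor, a lower number a stronger inhibitor. Compound 3 `O=C(COc1ccc2c(=O)ccoc2c1)Nc1cccc(NC(=O)c2ccc(Br)cc2)c1` gives 49 nM, the lowest of the three. Compound 1 `CN(C)c1ccc(C(=O)Nc2cccc(NC(=O)COc3ccc4c(c3)NC(=O)CC4)c2)cc1` gives 3140 nM and compound 2 `Cc1c(OCC(=O)Nc2cccc(NC(=O)c3ccc(N(C)C)cc3)c2)ccc2c(=O)ccoc12` gives 4160 nM; both gaps to compound 3 are beyond the scatter, but each of these compounds differs from compound 3 in more than one place, so neither isolates a single change.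

Compound 4 `Cn1ccc(S(=O)(=O)Nc2cccc(NC(=O)COc3ccc4c(=O)ccoc4c3)c2)n1` is not yet measured. It differs from compound 3 as follows: a group of 9 heavy atoms (4 carbon, 2 nitrogen, 2 oxygen, 1 sulfur; one five-membered aromatic ring with 2 hetero atoms) in place of a group of 9 heavy atoms (7 carbon, 1 oxygen, 1 bromine; one six-membered aromatic ring of carbon only), on a nitrogen on an aromatic ring. Going by the values given here, no measured pair shows this change alone, so the size of the step rests on judgement. Among the compounds with values here, the group that leaves is the one that compound 3 carries while holding the lowest number, and the group that enters has no precedent here. A step toward a higher number is expected, likely beyond the scatter, expressed as a 10-fold higher number from compound 3 to compound 4 (1.01 log units; beyond the scatter). Compound 4 is therefore estimated at 500 nM, with a range of 100 nM to 3000 nM.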

Compound 4, half-maximal inhibitory concentration: 1350 nM
Beside the measured number, compound 4's estimate is 2.7-fold (0.43 log units) below it, within the range that was stated.
By their numbers in this assay, from the lowest: compound 3; then compound 4; then compounds 1 and 2 (each within the scatter of the next).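

In this assay, going by these compounds alone, the group on a nitrogen on an aromatic ring is the first place where a single change can be read: replacing (4-bromophenyl)carbonyl with a sulfonyl group bearing a five-membered aromatic ring with 2 hetero atoms gives a 28-fold higher number from compound 3 to compound 4 (1.44 log units; beyond the scatter), a large step. The rest of the structure therefore does not by itself secure the low number of compound 3 49 nM, and this position responds strongly to what it carries. No accompanying data bear on the reason for the size of this step.

From the compounds shown here alone, the linking group and the ring change together here, so the share of each in the step remains open. A 4-bromophenylsulfonyl group, or a carbonyl carrying the same five-membered ring, would separate the two, and the effect of an amine or a carboxylic acid on that ring is also unknown.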